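A few compounds are considered here, and "the series" means these few. Any claim that something is new, unique, unknown or untested is made for them only; others in the source may bear on it.

Measured so far:
- compound 1 `O=C(Nc1cccc(-n2cc(-c3ccncc3)c(-c3ccc(Cl)c(O)c3)n2)c1)Nc1ccc(Cl)c(Cl)c1`: 2350 nM
- compound 2 `COc1cc(-c2nn(-c3cccc(NC(=O)c4ccc(Cl)c(C(F)(F)F)c4)c3)cc2-c2ccncc2)ccc1Cl`: 31800 nM
- compound 3 `COc1cc(-c2nn(-c3cccc(NC(=O)c4ccccc4)c3)cc2-c2ccncc2)ccc1Cl`: 7100 nM

Of the compounds shown here, three sharing a common core have been tested in a functional assay on SK-MEL-5 cells (Homo sapiens) for inhibition, read by sulforhodamine B assay, with a stated time of 48 h; a lower number here means that less compound is tolerated, a higher number that more compound is tolerated. Compound 1 gives the lowest number of the three: compound 3 stands nearest to it with a higher value, and compound 2 stands furthest with a still higher value. Among the compounds with values here, the only single-point comparison among the measured compounds is a 4.5-fold lower number from compound 2 to compound 3 (0.65 log units; beyond the scatter), a change on a carbonyl carbon in compounds whose cores also differ from compound 1 in other places, so it bears on the question only loosely.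

The unmeasured compound 4 `O=C(Nc1cccc(-n2cc(-c3ccncc3)c(-c3ccc(Cl)c(O)c3)n2)c1)Nc1cccc(C(F)(F)F)c1` differs from compound 1 in one place: 3-(trifluoromethyl)phenyl in place of 3,4-dichlorophenyl on an amide-type nitrogen. Within the data shown here, both groups are six-membered carbon rings carrying halogen-type substituents, and no measured pair shows this exact exchange on an amide-type nitrogen. Among the measured compounds shown here, the one step available, from compound 2 to compound 3, suggests that swapping substituted rings at this part of the molecule can move the number modestly, but here one substituted ring replaces another rather than giving way to a bare phenyl. The expected step of a 1.4-fold higher number from compound 1 to compound 4 (0.13 log units; within the scatter) is therefore small, likely within the scatter, with a slight lean toward a higher number. Compound 4 is estimated to give 3200 nM in this assay, within a range of 1200 nM to 9000 nM.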

Compound 4, concentration lethal to 50% of the cells: 13800 nM
Compound 4: middle estimate off by 4.3-fold (0.63 log units), on the low side; measured number outside the range, above it.
By their numbers in this assay, from the lowest: compound 1; then compounds 3 and 4 (each within the scatter of the next); then compound 2.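

In this assay, the step of a 5.9-fold higher number from compound 1 to compound 4 (0.77 log units; beyond the scatter) shows that on this amide-type nitrogen the choice of substituents on the ring matters, even though one substituted ring replaces another rather than a bare phenyl. The earlier step of a 4.5-fold lower number from compound 2 to compound 3 (0.65 log units; beyond the scatter) concerned a ring on a carbonyl carbon, so it could not show this; here, 3,4-dichlorophenyl and 3-(trifluoromethyl)phenyl each have one six-membered aromatic ring of carbon only, no hydrogen-bond donors or acceptors and no net charge, yet the measured number still moves beyond the scatter, so those shared features do not settle the outcome. No measurement shown here gives a reason for this difference.

The loss of the two chlorines and the gain of the trifluoromethyl arrive together in this one exchange, and the compounds shown do not separate them. Also open, from the compounds shown here alone, is how a ring carrying a single chlorine, a ring carrying a nitrile, or a bare phenyl would behave on this nitrogen in the core of compound 1.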